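Chloro for methylsulfanyl on a bicyclic nucleotide core

The source may hold more compounds than are shown below. What is called first, only, known or untested is meant among the compounds shown, and "the series" means these compounds.

Measured compounds:
compound 1 `CSc1nc(N)c2ncn([C@H]3[C@H](O)[C@H](O)[C@@]4(COP(=O)(O)OP(=O)(O)O)C[C@@H]34)c2n1` 0.4 nM
compound 2 `CSc1nc(N)c2ncn([C@H]3[C@H](O)[C@H](O)[C@@]4(COP(=O)(O)O)C[C@@H]34)c2n1` 590 nM

In an assay on cells with P2Y purinoceptor 1 (Homo sapiens) as the target, read by inositol phosphate accumulation (on this read-out lower numbers stand for an effect already at smaller amounts and higher numbers for an effect only at larger amounts of compound), compound 2 gives 590 nM and stands with the highest number of the two. Among the compounds with values here, the only step measured here, a 1500-fold higher number from compound 1 to compound 2 (3.17 log units; beyond the scatter), concerns the phosphorus-containing group on an oxygen and not the aromatic carbon.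

Compound 3 `Nc1nc(Cl)nc2c1ncn2[C@H]1[C@H](O)[C@H](O)[C@@]2(COP(=O)(O)O)C[C@@H]12` differs from compound 2 by chloro in place of methylsulfanyl on an aromatic carbon. Within the data shown here, no measured step bears on a change at this aromatic carbon, so for compound 3 a step in this assay of no clear size beyond the scatter is expected, a 1.5-fold higher number from compound 2 to compound 3 (0.18 log units; within the scatter). Compound 3 is therefore estimated at 900 nM, within 250 nM to 3500 nM.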

Compound 3, half-maximal effective concentration: 1890 nM
Estimate against measurement, compound 3: 2.1-fold (0.32 log units) below; the range from low to high includes it.
By their numbers in this assay, from the lowest: compound 1; then compound 2; then compound 3.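

In this assay, chloro in place of methylsulfanyl on the aromatic carbon between two ring nitrogen atoms gives a 3.2-fold higher number from compound 2 to compound 3 (0.51 log units; beyond the scatter) and so shows that this position responds to a change, though only modestly. Compound 3 keeps a measurable effect with the smaller chloro group. Nothing at hand explains this step.

Still open, going by these compounds, is how an amine, a methoxy group or a longer alkylsulfanyl chain would fare at this aromatic carbon. Also open, on these data alone, is whether chloro would give a similar step on compound 1, which carries the larger phosphorus-containing group.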